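From hydroxy to fluoro in a growth-inhibition series

A few compounds are considered here, and "the series" means these few. Any claim that something is new, unique, unknown or untested is made for them only; others in the source may bear on it.

In a functional assay on A498 cells (Homo sapiens) for inhibition (a higher number here means a weaker inhibitor of growth, a lower number a stronger inhibitor of growth), compound 1 `COc1ccc(-n2cnnc2-c2cc(OC)c(OC)c(OC)c2)cc1` gives 3800 nM. Compound 2 `COc1cc(-c2nncn2-c2ccc(N(C)C)cc2)cc(OC)c1OC` gives 490 nM, and compound 3 `COc1ccc(-n2cnnc2-c2cc(OC)c(OC)c(OC)c2)cc1O` gives 417 nM. Compound 3 and compound 2 cannot be told apart within the usual scatter, and both sit well below compound 1.

Compound 4 `COc1ccc(-n2cnnc2-c2cc(OC)c(OC)c(OC)c2)cc1F` carries fluoro in place of the hydroxy of compound 3, on an aromatic carbon ortho to a methoxy group and meta to a large group: fluoro in place of hydroxy on an aromatic carbon.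

The measured step that bears most directly on this is the one that introduced that hydroxy, a 9.1-fold lower number from compound 1 to compound 3 (0.96 log units; beyond the scatter). The other measured step, a 7.8-fold lower number from compound 1 to compound 2 (0.89 log units; beyond the scatter), changes a different group and offers only weak guidance. Among the compounds with values here, no fluoro compound has been measured yet, so it is unknown whether fluoro can keep any of the hydroxy gain. Most of that gain is expected to be lost, though perhaps not all of it.

The expected change is a 4.1-fold higher number from compound 3 to compound 4 (0.61 log units; beyond the scatter), a move to a higher number. The estimate for compound 4 is 1700 nM, with an expected range from 400 nM to 6000 nM.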

Compound 4, concentration for 50% growth inhibition: 8130 nM
For compound 4 the middle estimate is 4.8-fold (0.68 log units) below the measured one, and the stated range ends below it.
By their numbers in this assay, from the lowest: compounds 3 and 2 (each within the scatter of the next); then compound 1; then compound 4.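

Swapping hydroxy for fluoro costs far more than the hydroxy ever gained, with a 19-fold higher number from compound 3 to compound 4 (1.29 log units; beyond the scatter) against the earlier 9.1-fold lower number from compound 1 to compound 3 (0.96 log units; beyond the scatter). Fluoro therefore does more than fail to keep the gain: with a 2.1-fold higher number from compound 1 to compound 4 (0.33 log units; beyond the scatter), compound 4 is a weaker inhibitor of growth than compound 1, which carries only hydrogen at this place. This one aromatic carbon can thus move the result in either direction relative to hydrogen, depending on the single atom attached there, and no measurement available here explains the difference. From the compounds shown here alone, it remains open whether an amine or a chlorine atom at this same place would act more like hydroxy or more like fluoro. Also open, going by these compounds, is whether a methyl ether here would keep any of the hydroxy gain.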